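A few compounds are considered here, and "the series" means these few. Any claim that something is new, unique, unknown or untested is made for them only; others in the source may bear on it.

In a functional assay on KM12 cells (Homo sapiens) for antiproliferative activity (a higher number here means a weaker inhibitor of growth, a lower number a stronger inhibitor of growth), compound 2 (`COc1ccc(-c2nc3cc(F)ccc3s2)cc1`) gives 24600 nM and compound 3 (`COc1ccc(-c2nc3cc(F)ccc3s2)cc1F`) gives 20600 nM within the scatter of it, so these two numbers sit together. Compound 1 (`Cc1cc(-c2nc3ccccc3s2)ccc1N`) is recorded only as a limit of the assay (> 100000 nM). Compound 4 (`COc1ccc(-c2nc3cc(F)ccc3s2)cc1Br`) changes compound 2 by bromo in place of hydrogen on an aromatic carbon in the form of bromo in place of hydrogen on an aromatic carbon, ortho to a methoxy group. Going by the values given here, the only measured step that bears on this is fluoro in place of hydrogen at that same place (a 1.2-fold lower number from compound 2 to compound 3 (0.08 log units; within the scatter)). Among the compounds with values here, with compound 3 as the sole guide, no change beyond the scatter is expected in this assay in either direction. The expected step is small (a 1.4-fold lower number from compound 2 to compound 4 (0.14 log units; within the scatter)). For compound 4 the estimated value is 18000 nM (expected range 6000 nM to 50000 nM).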

Compound 4, concentration for 50% growth inhibition: 6700 nM
Beside the measured number, compound 4's estimate is 2.7-fold (0.43 log units) above it; low and high end bracket the measured number.
By their numbers in this assay, from the lowest: compound 4; then compounds 3 and 2 (each within the scatter of the next). At a limit, above all of these: compound 1.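

At this position, ortho to a methoxy group, the choice of halogen counts: in this assay bromo brings a 3.7-fold lower number from compound 2 to compound 4 (0.56 log units; beyond the scatter) and so moves the number beyond the scatter, which fluoro did not do. Bromo in place of fluoro at the same carbon gives a 3.1-fold lower number from compound 3 to compound 4 (0.49 log units; beyond the scatter) as well, so the two halogens are not interchangeable here. Nothing measured here bears on why they differ. The compounds shown leave open whether chloro at this position would sit with fluoro or with bromo, and whether an amine or a longer chain there would lower the number further.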